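Same atoms, new arrangement: estimating compound 4

This account rests on a few compounds, and the source may have more. Where it says the series, first, only, none or still open, it means among the compounds named here.

Compound 1 `CC[C@H]1[C@@H](N)CN1c1c(F)cc2c(=O)c(C(=O)O)cn(C3CC3)c2c1F` gives 55.9 ug/mL
Compound 2 `CC1(N)CN(c2c(F)cc3c(=O)c(C(=O)O)cn(C4CC4)c3c2F)C1` gives 0.8 ug/mL; 15.3 ug/mL (2 entries)
Compound 3 `C[C@H]1N(c2c(F)cc3c(=O)c(C(=O)O)cn(C4CC4)c3c2F)C[C@]1(C)N` gives 3.3 ug/mL

In a physicochemical assay for solubility, at pH 7.4 (a lower number here means a less soluble compound, a higher number a more soluble compound), compound 3 gives 3.3 ug/mL and so holds the lower of the two single numbers, well under compound 1. Compound 2 offers no single number, as the several entries of compound 2 in this assay, 0.8 ug/mL; 15.3 ug/mL (2 entries) shows with its two far-apart entries.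

Compound 4 `CN(C)C1CN(c2c(F)cc3c(=O)c(C(=O)O)cn(C4CC4)c3c2F)C1` has the same atoms as compound 3, joined differently: a group of 7 heavy atoms (5 carbon, 2 nitrogen; one four-membered non-aromatic ring with 1 hetero atom) in place of a group of 7 heavy atoms (5 carbon, 2 nitrogen; one four-membered non-aromatic ring with 1 hetero atom), on an aromatic carbon and the entering group is 3-(dimethylamino)azetidin-1-yl.

One measured step is a swap of this kind: a 17-fold lower number from compound 1 to compound 3 (1.23 log units; beyond the scatter) was large and beyond the scatter. Such a swap can therefore shift the number a long way. For the measured compounds named here, since compound 3 at 3.3 ug/mL sits low among the single numbers, a modest rise seems likelier than a fall, though the direction is uncertain. The expected change is a 2.7-fold higher number from compound 3 to compound 4 (0.44 log units; beyond the scatter) and it should stay well short of the large measured step. Compound 4 is expected at 9 ug/mL and 1.5 ug/mL to 50 ug/mL is its estimated range.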

Compound 4, solubility: 58 ug/mL
Compound 4: the middle estimate sits 6.4-fold (0.81 log units) below what was measured; the whole stated range lies below it.
By their numbers in this assay, from the lowest: compound 3; then compounds 1 and 4 (each within the scatter of the next).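

In this assay, for the compounds shown here, the earlier compounds showed only a fall at this aromatic carbon, whereas an 18-fold higher number from compound 3 to compound 4 (1.24 log units; beyond the scatter) shows that exchanging one group for another with the same atoms can also bring a large rise. With a 1.0-fold higher number from compound 1 to compound 4 (0.02 log units; within the scatter) the group of compound 1 and 3-(dimethylamino)azetidin-1-yl cannot be told apart in this measurement, even though the latter has no hydrogen-bond donors and no defined stereocentres. Nothing measured here explains why compound 3 differs so much from compound 4.

As far as these compounds go, whether the number in this assay would hold with a longer chain on the nitrogen, as in 3-(diethylamino)azetidin-1-yl, remains open. So does the outcome for a hydroxyl group in place of the amine on the four-membered ring.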